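The source may report more compounds than this note shows. Statements on the series, on what has been measured and on what is new or still open speak of the compounds shown alone.

Working notes on the series.

Of the compounds shown here, three have been measured. Compound 1, `CN(c1ncnc2c1ncn2CC1CC1)C1CC1`, gives 7.5 mg/kg in a functional assay on the whole organism for antagonist activity, with Rattus norvegicus as the target; on this read-out lower numbers stand for an effect already at smaller amounts and higher numbers for an effect only at larger amounts of compound. Compound 2, `CCCn1cnc2c(NC3CC3)ncnc21`, gives 6 mg/kg in this assay. Compound 3, `CC(C)Cn1cnc2c(NC3CC3)ncnc21`, gives 10 mg/kg in this assay. All three numbers sit within the usual scatter of one another, so no ordering among them is claimed.

For the measured compounds named here, the one change that is measured is methyl in place of hydrogen on a saturated chain carbon bound to two saturated chain carbons. Its step is a 1.7-fold higher number from compound 2 to compound 3 (0.22 log units; within the scatter). The difference between the cores of compound 1 and compound 2 is not broken down here.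

Not yet measured is compound 4, `CCN(c1ncnc2c1ncn2CC1CC1)C1CC1`. Relative to compound 1 the change is methyl in place of hydrogen on a saturated chain carbon bound to a nitrogen on an aromatic ring. This is the same kind of change as the measured one, not the same: in compound 3 the new methyl sits on a saturated chain carbon bound to two saturated chain carbons, whereas in compound 4 it sits on a saturated chain carbon bound to a nitrogen on an aromatic ring. Going by the values given here, with only one measured instance, and that one within the scatter, the expectation rests on compound 1 at 7.5 mg/kg together with the step of a 1.7-fold higher number from compound 2 to compound 3 (0.22 log units; within the scatter). From compound 1 to compound 4 the expected step is a 1.2-fold higher number from compound 1 to compound 4 (0.08 log units; within the scatter), small and uncertain in direction. Compound 4 is therefore estimated at 9 mg/kg in this assay, with a likely range from 4.5 mg/kg to 18 mg/kg.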

Compound 4, dose for half-maximal effect: 20 mg/kg
Compound 4: middle estimate off by 2.2-fold (0.35 log units), on the low side, outside the stated range (above it).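

In this assay, methyl in place of hydrogen on a saturated chain carbon bound to a nitrogen on an aromatic ring gives a 2.7-fold higher number from compound 1 to compound 4 (0.43 log units; beyond the scatter), a modest step. The two instances of this change in the series cannot be told apart, as the gap between them stays inside what two such steps would scatter: the same change on two cores in this assay, a 1.7-fold higher number (0.22 log units; within the scatter) from compound 2 to compound 3 and a 2.7-fold higher number (0.43 log units; beyond the scatter) from compound 1 to compound 4, 1.6-fold (0.20 log units) apart, within the scatter of two such steps. For the compounds shown here, this gives no sign that the core of compound 1 and the core of compound 2 respond differently to the added methyl, but it does not show that the step carries over unchanged from one core to another, as there are only two instances, the methyl stands at a different place in each, and only the step on the core of compound 1 lies beyond the scatter.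

The compounds shown leave open whether the higher number continues with a longer chain in place of the ethyl, or changes when that chain ends in an amine or a carboxylic acid. They also leave open how the same methyl behaves on a third core, which would be needed before any rule for this change could be stated for the series.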